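The source may report more compounds than this note shows. Statements on the series, on what has been measured and on what is new or still open speak of the compounds shown alone.

Three compounds built on one shared core were measured in an ADME assay on microsomes from liver (Rattus norvegicus, strain Sprague-Dawley) for metabolic stability, read by HPLC, using NADPH, with stated times of 5 min and 60 min, tested at 10 uM; a lower number here means that the compound disappears faster, a higher number that the compound lasts longer. Compound 1 `CC(C)S(=O)(=O)Nc1ccc(CNC(=O)c2ccc(C(C)(C)C)cc2)c(Cl)c1` gives 0.983 h, compound 2 `CS(=O)(=O)Nc1ccc(CNC(=O)c2ccc(C3(C(F)(F)F)CC3)cc2)c(Cl)c1` gives 3.03 h, and compound 3 `CC(C)Oc1ccc(C(=O)NCc2ccc(NS(C)(=O)=O)cc2Cl)cc1` gives 1.85 h. Compound 2 thus stands at the top of the three numbers shown: compound 3 sits within the scatter of it, while compound 1 lies beyond the scatter. Compound 4 `CC(C)(O)c1ccc(C(=O)NCc2ccc(NS(C)(=O)=O)cc2Cl)cc1` differs from compound 2 in one place: 1-hydroxy-1-methylethyl in place of 1-(trifluoromethyl)cyclopropyl on an aromatic carbon. Among the measured compounds shown here, the single measured step that bears on an exchange at this aromatic carbon is a 1.6-fold lower number from compound 2 to compound 3 (0.21 log units; within the scatter). On that basis only a modest change is expected, and the step of a 1.4-fold lower number from compound 2 to compound 4 (0.14 log units; within the scatter) is estimated to stay near the scatter. Compound 4 is expected to give about 2.2 h in this assay, with a range from 1.2 h to 4 h.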

Compound 4, half-life in the Rattus norvegicus assay: 20.2 h
Compound 4: middle estimate off by 9.2-fold (0.96 log units), on the low side, and the stated range ends below it.
By their numbers in the Rattus norvegicus assay, from the lowest: compounds 1, 3 and 2 (each within the scatter of the next, the first and the last beyond it); then compound 4.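

In the Rattus norvegicus assay, 1-hydroxy-1-methylethyl brings a 6.7-fold higher number from compound 2 to compound 4 (0.82 log units; beyond the scatter) and an 11-fold higher number from compound 3 to compound 4 (1.04 log units; beyond the scatter), so an exchange at this aromatic carbon can move the half-life well beyond the scatter, which the step between compound 2 and compound 3 did not show. In a physicochemical assay for solubility (on this read-out higher numbers stand for higher solubility and lower numbers for lower solubility), compound 2 gives 2.9 ug/mL and compound 4 gives 48 ug/mL. In the physicochemical assay, the same exchange also raises the number: the measured solubility of compound 2, 2.9 ug/mL, and of compound 4, 48 ug/mL, a 17-fold higher number (1.22 log units; beyond the scatter)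

Going by these compounds, what stays open is whether a group with an amine in place of the hydroxy, such as 1-amino-1-methylethyl, or with a methyl ether, such as 1-methoxy-1-methylethyl, would give a similar half-life at this carbon.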